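The source may hold more compounds than are shown below. What is called first, only, known or untested is meant among the compounds shown, and "the series" means these compounds.

In an ADME assay on microsomes from liver (Homo sapiens) for metabolic stability (on this read-out higher numbers stand for a more stable compound and lower numbers for a less stable compound), the measured compounds are:

- compound 1 (`C/C(=C/CN(C[C@H]1Cc2ccccc2CN1)[C@H]1CCCc2cccnc21)CN`) gives 100%
- compound 2 (`C/C(CN)=C(\F)CN(C[C@H]1Cc2ccccc2CN1)[C@H]1CCCc2cccnc21`) gives 100%
- compound 3 (`C/C(CN(C[C@H]1Cc2ccccc2CN1)[C@H]1CCCc2cccnc21)=C(\F)CN`) gives 51%

Compound 1 shares the top of these three numbers (there is no change at the digits printed from compound 1 to compound 2 (within the scatter)), and the only fall from it is a large one (a number 49 percentage points lower from compound 1 to compound 3 (beyond the scatter)). Compound 4 (`N[C@H]1CC[C@H](N(C[C@H]2Cc3ccccc3CN2)[C@H]2CCCc3cccnc32)CC1`) has not yet been measured and differs from compound 1 in one place (a group of 7 heavy atoms (6 carbon, 1 nitrogen; one six-membered non-aromatic ring of carbon only) in place of a group of 6 heavy atoms (5 carbon, 1 nitrogen; no ring), on an amine nitrogen). For the measured compounds named here, no measured step makes this exchange, so the evidence is indirect. It comes from changes within the same open chain, where compound 2 keeps its number while compound 3 does not (a number 49 percentage points lower from compound 2 to compound 3 (beyond the scatter)). Changes to this chain can therefore be silent or large in this assay, and the replacement of the whole chain by a ring is untested. Going by the values given here, a moderate fall is expected, smaller than the one seen for compound 3, though no change beyond the scatter remains possible. The expected step is a number 20 percentage points lower from compound 1 to compound 4 (beyond the scatter). For compound 4 the estimated value is 80%, with an expected range from 50% to 100%.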

Compound 4, percent of the compound remaining: 95%
Beside the measured number, compound 4's estimate is 15 percentage points below it; measured number inside the range.
By their numbers in this assay, from the lowest: compound 3; then compounds 4, 1 and 2 (each within the scatter of the next).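

In this assay the open chain on the amine nitrogen can be replaced by 4-aminocyclohexyl without a change beyond the scatter (a number 5 percentage points lower from compound 1 to compound 4 (within the scatter)), and the same holds against the fluorinated chain of compound 2 (a number 5 percentage points lower from compound 2 to compound 4 (within the scatter)). The ring does not share the large shortfall of the isomeric fluorinated chain (a number 44 percentage points higher from compound 3 to compound 4 (beyond the scatter)), so an open chain is not needed at this position for the number to stay high. Nothing shown here gives a reason for any of these steps.

The compounds shown leave open whether a cyclopentyl ring carrying the same amine, or a hydroxyl or carboxylic acid in place of that amine on the cyclohexyl ring, would hold this level. They also leave open how the other arrangement of the two defined stereocentres of 4-aminocyclohexyl would read.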